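The source may report more compounds than this note shows. Statements on the series, on what has been measured and on what is new or still open speak of the compounds shown alone.

Compound 3 `CCCn1cnc(CN2CCN(c3cccc4[nH]c(-c5ccc(C(C)(C)C)cc5)nc34)CC2)c1C` gives 47 nM in an assay on isolated protein for displacement of a labelled ligand from Gonadotropin-releasing hormone receptor (Rattus norvegicus); on this read-out lower numbers stand for stronger inhibition and higher numbers for weaker inhibition. Among the three compounds measured, compound 3 stands second highest: nearest is compound 1 `Cc1nc(CN2CCN(c3cccc4[nH]c(-c5ccc(C(C)(C)C)cc5)nc34)CC2)c[nH]1`, which in this assay gives 28 nM, and furthest is compound 2 `Cc1nc(C)c(CN2CCN(c3cccc4[nH]c(-c5ccc(C(C)(C)C)cc5)nc34)CC2)o1`, which in this assay gives 740 nM. The step of a 1.7-fold higher number from compound 1 to compound 3 (0.22 log units; within the scatter) lies within the scatter, whereas the steps of a 26-fold higher number from compound 1 to compound 2 (1.42 log units; beyond the scatter) and a 16-fold lower number from compound 2 to compound 3 (1.20 log units; beyond the scatter) are large. Compound 4 `CCCCn1cnc(CN2CCN(c3cccc4[nH]c(-c5ccc(C(C)(C)C)cc5)nc34)CC2)c1C` differs from compound 3 by methyl in place of hydrogen on a saturated chain carbon, three bonds along the chain from an aromatic nitrogen, that is, propyl becomes butyl on the imidazole nitrogen. For the measured compounds named here, no measured step bears on a chain-length change of this kind: the two large steps both involve exchanging one heterocycle for another, and the only step that brings in the propyl chain together with its neighbouring methyl, a 1.7-fold higher number from compound 1 to compound 3 (0.22 log units; within the scatter), stays within the scatter. A step of no more than the scatter is therefore expected for compound 4, as a 1.1-fold higher number from compound 3 to compound 4 (0.03 log units; within the scatter). Compound 4 is estimated at 50 nM in this assay, with a range from 20 nM to 130 nM.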

Compound 4, half-maximal inhibitory concentration: 49 nM
The estimate for compound 4 lay 1.0-fold (0.01 log units) above the measured number; the measured number falls inside the stated range.
By their numbers in this assay, from the lowest: compounds 1, 3 and 4 (each within the scatter of the next); then compound 2.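

In this assay, the step of methyl in place of hydrogen on a saturated chain carbon, three bonds along the chain from an aromatic nitrogen, turning propyl into butyl, gives a 1.0-fold higher number from compound 3 to compound 4 (0.02 log units; within the scatter), so this position takes the extra carbon with no step beyond the scatter. The butyl compound also keeps the standing of the propyl compound against the other two, with a 1.8-fold higher number from compound 1 to compound 4 (0.24 log units; within the scatter) and a 15-fold lower number from compound 2 to compound 4 (1.18 log units; beyond the scatter), so the large gap to the 2,4-dimethyl-1,3-oxazol-5-yl compound stays in place. Nothing at hand explains why the longer chain is accepted here.

The compounds shown leave open whether this holds for a hexyl chain, a branched chain such as isobutyl, a benzyl group, or a chain ending in an amine or a carboxylic acid. They also leave open what the ring methyl contributes apart from the chain on the imidazole nitrogen.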